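Chloro for Trifluoromethyl on the Aromatic Carbon

The compounds below may be only part of what the source reports. "The series", "measured", "known", "first", "only" and "open" are said of these compounds alone.

compound 1 `CC1=CC[C@H](C(C)C)c2cc(C)c(OC(=O)Nc3ccccc3)cc21`: 100%
compound 2 `CC1=CC[C@H](C(C)C)c2cc(C)c(OC(=O)c3ccc([N+](=O)[O-])cc3)cc21`: 16.8%
compound 3 `CC1=CC[C@H](C(C)C)c2cc(C)c(OC(=O)c3ccc(C(F)(F)F)cc3)cc21`: 14.7%

Of the compounds shown here, three sharing one core have been measured in a functional assay on U-251 cells (Homo sapiens) for antiproliferative activity, read by sulforhodamine B assay, with a stated time of 48 h, tested at 50 uM; on this read-out lower numbers stand for less inhibition and higher numbers for more inhibition at the one concentration tested (going by the name of the read-out). Compound 1 gives 100%, compound 2 gives 16.8% and compound 3 gives 14.7%. Compound 3 thus stands at the lowest of the three numbers, although the gap to compound 2 lies within the scatter, while compound 1 sits far above it.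

Two steps connect these compounds: a number 83.2 percentage points lower from compound 1 to compound 2 (beyond the scatter), and a number 2.1 percentage points lower from compound 2 to compound 3 (within the scatter). The second step is the one that bears on what follows, since it also exchanges the group on the aromatic carbon and left the read-out essentially unchanged.

Compound 4 `CC1=CC[C@H](C(C)C)c2cc(C)c(OC(=O)c3ccc(Cl)cc3)cc21` is not yet measured. It differs from compound 3 by chloro in place of trifluoromethyl on an aromatic carbon. Given that the earlier exchange at this same place, from compound 2 to compound 3, moved the number only within the scatter, a step of no more than a number 2.3 percentage points higher from compound 3 to compound 4 (within the scatter) is expected here as well. Compound 4 is therefore estimated at 17%, with a range from 5% to 35%.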

Compound 4, a percentage reported as inhibition, at one concentration (the size of the read-out at that concentration, not a potency): 25.6%
Estimate against measurement, compound 4: 8.6 percentage points below; measured number inside the range.
By their numbers in this assay, from the lowest: compounds 3, 2 and 4 (each within the scatter of the next, the first and the last beyond it); then compound 1.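

In this assay, an exchange at this aromatic carbon, para to a large group, now gives a step beyond the scatter (a number 10.9 percentage points higher from compound 3 to compound 4 (beyond the scatter)), so the group here can matter, though only modestly. Chloro and nitro are not told apart at this place (a number 8.8 percentage points higher from compound 2 to compound 4 (within the scatter)), which means that the three groups fall into no clear order and only chloro and trifluoromethyl are separated. Both exchanges remain small beside the change at the carbonyl carbon (a number 74.4 percentage points lower from compound 1 to compound 4 (beyond the scatter)), and no evidence is at hand to explain the chloro step.

On these data alone, it remains open whether an amine or a carboxylic acid at this aromatic carbon would move the number further than chloro does. Also open, as far as these compounds go, is whether a chloro on the anilino ring of compound 1 would keep its read-out.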